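Methyl on the chain carbon of compound 2

This account rests on a few compounds, and the source may have more. Where it says the series, first, only, none or still open, it means among the compounds named here.

In a functional assay on the whole organism for agonist activity, with Mus musculus as the target (a lower number here means that less compound is needed, a higher number that more compound is needed for the effect), compound 1 `O=C1NCCN1CC#CCn1ccnc1` gives only a limit, > 100 mg/kg. Among the compounds with values here, compound 2 `CN1CCN(CC#CCn2ccnc2)C1=O`, with 0.97 mg/kg, holds the only actual number. Within the data shown here, the one measured step, an at least 100-fold lower number from compound 1 to compound 2 (2.01 log units; beyond the scatter), was large, but it placed methyl on an amide-type nitrogen in a ring. Compound 3 `CC(C#CCn1ccnc1)N1CCN(C)C1=O` carries methyl in place of hydrogen on a saturated chain carbon bound to an amide-type nitrogen in a ring and a triple-bonded carbon. This lies at a different place, so the earlier step shows only that a single methyl can shift this assay strongly. A higher number is expected, beyond the scatter, with wide uncertainty. The expected step is an 8.2-fold higher number from compound 2 to compound 3 (0.92 log units; beyond the scatter). For compound 3 the estimated dose is 8 mg/kg, within an expected range of 1.5 mg/kg to 60 mg/kg.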

Compound 3, dose for half-maximal effect: 97 mg/kg
Beside the measured number, compound 3's estimate is 12-fold (1.08 log units) below it; the measured number lies above the stated range.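

Methyl in place of hydrogen on this saturated chain carbon gives a 100-fold higher number from compound 2 to compound 3 (2.00 log units; beyond the scatter) in this assay. A single methyl therefore moves the number strongly at a second place in the series, and here upward, whereas methyl on the amide-type nitrogen in a ring lowered it. Further rises from this carbon may read only as a limit, as compound 1 does: the limit of > 100 mg/kg in this assay, at which 1 of the 3 values shown sits.

On these data alone, whether an ethyl or a hydroxyl on this carbon would shift the number as methyl does remains open. The compounds shown also leave open how a longer chain on the amide-type nitrogen would read.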